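The compounds below may be only part of what the source reports. "The series", "measured", "known", "first", "only" and "open" are said of these compounds alone.

Working notes on the series. In a functional assay on HCT-15 cells (Homo sapiens) for cytotoxicity (a lower number here means that less compound is needed, a higher number that more compound is needed for the effect), compound 1 (`CC(=O)C(O)C(O)C/C(C)=C\CC[C@H](C)/C=C/C=C(\C)CCCC1=CC(=O)OC1O`) gives 4.6 ug/mL and compound 2 (`C/C(=C\CCc1ccoc1)C[C@@H]1C=C(C/C=C/c2ccoc2)C(=O)O1`) gives 4.2 ug/mL with the two values within the scatter of each other. Compound 3 (`COC1C=C(CCC/C(C)=C/C=C/[C@@H](C)CC/C=C(/C)C[C@H]2OC(=O)C(C)=C2O)C(=O)O1`) gives 33 ug/mL as the highest number of the three, beyond the scatter from both. Compound 4 (`CC1=C(O)[C@@H](C/C(C)=C\CC[C@H](C)/C=C/C=C(\C)CCCC2=CCN(CC(=O)O)C2=O)OC1=O`) is not yet measured and differs from compound 3 by a group of 10 heavy atoms (6 carbon, 1 nitrogen, 3 oxygen; one five-membered non-aromatic ring with 1 hetero atom) in place of a group of 8 heavy atoms (5 carbon, 3 oxygen; one five-membered non-aromatic ring with 1 hetero atom), on a saturated chain carbon, three bonds along the chain from a double-bonded chain carbon on a saturated chain carbon, three bonds along the chain from a double-bonded chain carbon. Within the data shown here, no measured pair shows such a change, so the expectation is loose. A lower number is expected in this assay with a 1.7-fold lower number from compound 3 to compound 4 (0.22 log units; within the scatter) as the expected step, which would not lie beyond the scatter. For compound 4 the estimated value is 20 ug/mL with an expected range from 6 ug/mL to 60 ug/mL at this stage.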

Compound 4, concentration for half-maximal effect: > 30 ug/mL
Compound 4: no number, only a limit; the forecaster's own chance of this, stated with the estimate: 15%; at least 1.5-fold (0.17 log units) between middle value and limit.
By their numbers in this assay, from the lowest: compounds 2 and 1 (each within the scatter of the next); then compound 3.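

In this assay, among these compounds, compound 4 gives > 30 ug/mL, a limit and not a number, so no step from compound 3 to compound 4 can be read. As far as these compounds go, how the entering group changes the number in this assay remains open.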